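A few compounds are considered here, and "the series" means these few. Any claim that something is new, unique, unknown or untested is made for them only; others in the source may bear on it.

Measured compounds:
- compound 1 `COc1ccccc1N1CCN(CCCNC(=O)Cc2c[nH]c3ccccc23)CC1`: 7.94 nM
- compound 2 `COc1ccccc1N1CCN(CCCNC(=O)CCc2c[nH]c3ccccc23)CC1`: 195 nM

Both numbers come from an assay on isolated protein (Vas deferens, strain Sprague-Dawley) for antagonist activity at Alpha-1A adrenergic receptor (Rattus norvegicus), with a stated time of 20 min; on this read-out higher numbers stand for weaker binding and lower numbers for tighter binding. For the measured compounds named here, compound 1 holds the lower of the two values; the only other measured compound is compound 2, and the step of a 25-fold higher number from compound 1 to compound 2 (1.39 log units; beyond the scatter) is a large rise. Going by the values given here, that step inserts one saturated chain carbon between the amide carbonyl and the indole and is the only change measured so far.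

Compound 3 `COc1ccccc1N1CCN(CCCNC(=O)c2cc3cc(Cl)ccc3[nH]2)CC1` has not yet been measured in this assay. It differs from compound 1 in one place: 5-chloro-1H-indol-2-yl in place of (1H-indol-3-yl)methyl on a carbonyl carbon. Here the saturated chain carbon is removed rather than extended, the indole is joined to the carbonyl through a different ring carbon, and a chlorine is added. Among the compounds with values here, no measured step covers this change directly. The step from compound 1 to compound 2 shows only that the series responds strongly to the spacing between carbonyl and indole; it does not tell which way a shorter, directly attached indole moves. The expectation is therefore a modest change, a 1.9-fold higher number from compound 1 to compound 3 (0.28 log units; within the scatter), with wide uncertainty in either direction. Compound 3 is estimated at 15 nM in this assay, with a likely range from 3 nM to 80 nM.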

Compound 3, dissociation constant: 47.9 nM
Compound 3: the middle estimate sits 3.2-fold (0.50 log units) below what was measured, and the stated range covers the measured number.
By their numbers in this assay, from the lowest: compound 1; then compound 3; then compound 2.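

In this assay, 5-chloro-1H-indol-2-yl in place of (1H-indol-3-yl)methyl on the carbonyl carbon gives a 6.0-fold higher number from compound 1 to compound 3 (0.78 log units; beyond the scatter), a modest rise beyond the scatter, whereas the chain extension gave the large 25-fold higher number from compound 1 to compound 2 (1.39 log units; beyond the scatter); this position therefore accepts an indole with no saturated chain carbon at a moderate cost, and changes here need not cost as much as that extension. Compound 1 keeps the lowest number of the three, so neither change has improved on (1H-indol-3-yl)methyl, and the new step combines loss of the chain carbon, a different point of attachment on the indole and the added chlorine, so the rise cannot be assigned to any one of these. No available evidence bears on the origin of this rise.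

On these data alone, the separate contributions remain open: the unsubstituted 1H-indol-2-yl and the 1H-indol-3-yl group, each on the carbonyl carbon, would divide the step into its parts. Also open, as far as these compounds go, is how fluorine, methyl or methoxy in place of the chlorine would read in this assay.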